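This account rests on a few compounds, and the source may have more. Where it says the series, first, only, none or still open, it means among the compounds named here.

Compound 2 `CC(C)=CCC/C(C)=C/COc1ccc(C2CC2C(=O)NNC(=O)c2ccncc2)cc1` gives, in a functional assay on U-373MG ATCC cells (Homo sapiens) for inhibition, read by MTT assay, with a stated time of 72 h (a higher number here means a weaker inhibitor, a lower number a stronger inhibitor), a value of 84000 nM, the higher of the two numbers measured here. Among the measured compounds shown here, its nearest neighbour is compound 1 `CC(C)=CCC/C(C)=C/COc1ccc(C2CC2C(=O)NNc2nncc3ccccc23)cc1`, which in this assay gives 9000 nM; the only step measured, a 9.3-fold higher number from compound 1 to compound 2 (0.97 log units; beyond the scatter), replaces a group on the amine nitrogen of the hydrazide terminus. Compound 3 `CC(C)=CCOc1ccc(C2CC2C(=O)NNC(=O)c2ccncc2)cc1` keeps that terminus of compound 2 unchanged and differs only in the ether side chain, with hydrogen in place of 3-methylbut-2-en-1-yl on a saturated chain carbon bound to a double-bonded chain carbon. For the measured compounds named here, no measured step touches this side chain, so the one step available, a 9.3-fold higher number from compound 1 to compound 2 (0.97 log units; beyond the scatter), offers no guide to the direction or size of the change; the shortening from 3,7-dimethylocta-2,6-dien-1-yl to 3-methylbut-2-en-1-yl is untested. Compound 3 is therefore expected, in this assay, to give about 110000 nM, within 30000 nM to 450000 nM, a step of a 1.3-fold higher number from compound 2 to compound 3 (0.12 log units; within the scatter) that is estimated to lie within the scatter.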

Compound 3, half-maximal inhibitory concentration: > 100000 nM
Compound 3: no number, only a limit (the forecaster's own chance of this, stated with the estimate: 30%); the middle value lies beyond the limit too.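

In this assay compound 3 reaches a limit of the assay and not a number: the limit of > 100000 nM in this assay, at which 1 of the 3 values shown sits. Shortening 3,7-dimethylocta-2,6-dien-1-yl to 3-methylbut-2-en-1-yl, the only change shown on this side chain, reads as an at least 1.1-fold higher number from compound 2 to compound 3 (0.07 log units; that floor lies within the scatter), so the true size of the step is unknown. The earlier step concerned only the hydrazide terminus, whereas this side chain now has a first reading, though a one-sided one: the shorter chain brings no lower number.

The compounds shown leave open how far compound 3 lies past its limit, and whether a chain longer than 3,7-dimethylocta-2,6-dien-1-yl or a saturated alkyl chain would change the number at this place. They also leave open what 3-methylbut-2-en-1-yl would give on the terminus of compound 1.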